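A Flat Set of Values and a Methoxy Swap

The source may report more compounds than this note shows. Statements on the series, on what has been measured and on what is new or still open speak of the compounds shown alone.

In a functional assay on MCF7 cells (Homo sapiens) for antiproliferative activity, read by MTT assay, with a stated time of 72 h (on this read-out higher numbers stand for weaker inhibition and lower numbers for stronger inhibition), compound 1 `NC1CCc2nc(-c3ccncc3)nc(Nc3ccc(F)cc3)c2C1` gives 16000 nM, compound 2 `NC1CCc2nc(-c3ccncc3)nc(Nc3cccc(F)c3)c2C1` gives 13900 nM and compound 3 `CN(C)c1ccc(Nc2nc(-c3ccncc3)nc3c2CC(N)CC3)cc1` gives 15800 nM. Compound 3 therefore stands within the scatter of both neighbours, as a 1.0-fold lower number from compound 1 to compound 3 (0.01 log units; within the scatter) and a 1.1-fold higher number from compound 2 to compound 3 (0.06 log units; within the scatter) show. Compound 4 `COc1cccc(Nc2nc(-c3ccncc3)nc3c2CC(N)CC3)c1` carries 3-methoxyphenyl in place of 4-(dimethylamino)phenyl on a nitrogen on an aromatic ring. The measured steps at this same place, a 1.2-fold lower number from compound 1 to compound 2 (0.06 log units; within the scatter) and the two above, all stay within the scatter, so no step beyond the scatter is expected in this assay. The estimated step is a 1.1-fold lower number from compound 3 to compound 4 (0.04 log units; within the scatter). For compound 4 the expected value is 14500 nM, with an estimated range of 8000 nM to 25000 nM.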

Compound 4, half-maximal inhibitory concentration: 15800 nM
For compound 4 the middle estimate is 1.1-fold (0.04 log units) below the measured one; low and high end bracket the measured number.
By their numbers in this assay, from the lowest: compounds 2, 3, 4 and 1 (each within the scatter of the next).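

In this assay, the methoxy-bearing compound 4 sits within the scatter of all three earlier compounds (no change at the digits printed from compound 3 to compound 4 (within the scatter); a 1.1-fold higher number from compound 2 to compound 4 (0.06 log units; within the scatter); a 1.0-fold lower number from compound 1 to compound 4 (0.01 log units; within the scatter)). An oxygen-linked group on the aromatic ring, with 3-methoxyphenyl on a nitrogen on an aromatic ring, thus joins the fluoro and dimethylamino groups without separating any of these four compounds at this position. No evidence at hand accounts for this flat result. The compounds shown leave open whether a carboxylic acid on this aromatic ring, or a longer chain in place of the ring, would give a step beyond the scatter.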